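A few compounds are considered here, and "the series" means these few. Any claim that something is new, unique, unknown or untested is made for them only; others in the source may bear on it.

Compound 1 `CCO/C(O)=C1\C(COCCNC(C)=O)=NC(C)=C(C(=O)OC)C1c1ccccc1Cl` and compound 2 `CCO/C(O)=C1\C(COCCNC(=O)NCC(N)=O)=NC(C)=C(C(=O)OC)C1c1ccccc1Cl` share a core and differ only in the group on the carbonyl carbon of the side chain. In a functional assay (aorta) with Rattus norvegicus as the target (on this read-out higher numbers stand for weaker inhibition and lower numbers for stronger inhibition), compound 1 gives 15.9 nM, and in this assay compound 2 gives 20 nM. Among the measured compounds shown here, the only step recorded so far is a 1.3-fold higher number from compound 1 to compound 2 (0.10 log units; within the scatter), so compound 2 holds the higher of the two numbers, with compound 1 the nearest and within the scatter of it.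

Compound 3 `CCO/C(O)=C1\C(COCCN(C)S(N)(=O)=O)=NC(C)=C(C(=O)OC)C1c1ccccc1Cl` is not yet measured. It differs from compound 2 by the following change: methyl(sulfamoyl)amino in place of ((carbamoylmethyl)carbamoyl)amino on a saturated chain carbon, two bonds along the chain from an oxygen on a saturated carbon

For the measured compounds named here, the one measured step, from compound 1 to compound 2, touched the same side chain but altered a smaller part of it, and it stayed within the scatter. Going by the values given here, no measured pair speaks to the exchange of the whole terminal group, so the expectation rests on that one quiet step. The step from compound 2 to compound 3 is therefore expected to be a 1.1-fold lower number from compound 2 to compound 3 (0.05 log units; within the scatter), with no direction beyond the scatter. For compound 3 in this assay the estimate is 18 nM, with a range from 6 nM to 55 nM.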

Compound 3, half-maximal inhibitory concentration: 25.1 nM
Beside the measured number, compound 3's estimate is 1.4-fold (0.14 log units) below it; low and high end bracket the measured number.
By their numbers in this assay, from the lowest: compounds 1, 2 and 3 (each within the scatter of the next).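

Replacing the whole terminal group on a saturated chain carbon, two bonds along the chain from an oxygen on a saturated carbon, gives a 1.3-fold higher number from compound 2 to compound 3 (0.10 log units; within the scatter) in this assay and stays within the scatter. Set against the acetamido group, the same methyl(sulfamoyl)amino group gives a 1.6-fold higher number from compound 1 to compound 3 (0.20 log units; within the scatter) and also stays within the scatter, so the three compounds cannot be separated on this read-out. The earlier step changed only what stood on the carbonyl carbon, whereas this one removes that carbonyl altogether, brings in a sulfur and takes the count of hydrogen-bond donors in the group from 3 to 1, and the numbers still lie together; nothing given here accounts for this.

Going by these compounds, how a carboxylic acid or a primary amine in that place would read stays open, as does a longer chain carrying the same methyl(sulfamoyl)amino group. Also open, on these data alone, is what the methyl on the nitrogen of compound 3 contributes on its own, and whether any group at this position can move the number beyond the scatter.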